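A Second Methoxy on an Inactive Compound

The source may report more compounds than this note shows. Statements on the series, on what has been measured and on what is new or still open speak of the compounds shown alone.

So far, two compounds have been tested in a functional assay on HeLa cells (Homo sapiens) for cytotoxicity, read by MTT assay, with a stated time of 48 h; a higher number here means a weaker inhibitor, a lower number a stronger inhibitor. Compound 1 (`COc1ccc(/C=C/C(=O)/C=C/c2cc3ccccc3nc2Cl)c(OC)c1`) gives only a limit of the assay, > 10000 nM. Compound 2 (`COc1ccc(/C=C/C(=O)/C=C/c2cc3ccccc3nc2Oc2ccc(Br)cc2)cc1`) also gives only a limit, > 10000 nM. Compound 3 (`COc1ccc(/C=C/C(=O)/C=C/c2cc3ccccc3nc2Oc2ccc(Br)cc2)c(OC)c1`) differs from compound 2 by methoxy in place of hydrogen on an aromatic carbon, turning 4-methoxyphenyl into 2,4-dimethoxyphenyl. Compound 1 already carries 2,4-dimethoxyphenyl and still gives > 10000 nM, so no large gain is expected. The estimated change is a step that the limit leaves unreadable from compound 2 to compound 3, expected to stay within the scatter. Compound 3 is estimated at 12000 nM, with an expected range of 4000 nM to 30000 nM.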

Compound 3, half-maximal inhibitory concentration: > 10000 nM
Compound 3: a limit, no number; the forecaster's own chance of this, stated with the estimate: 65%; the middle value lies beyond the limit too.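

No step can be read from compound 2 or compound 1 to compound 3, because each result is only a limit: the limit of > 10000 nM in this assay, at which 3 of the 3 values shown sit.

The compounds shown leave open how far each lies beyond that limit, and whether either change alters the result at all.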